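One Methyl Added: Expected Growth Inhibition for Compound 4

The source may hold more compounds than are shown below. What is called first, only, known or untested is meant among the compounds shown, and "the series" means these compounds.

Measured compounds:
Compound 1 `Cc1cccc(/C(N)=N/NC(=S)N2CCN(c3ccccn3)CC2)n1`: 57.4%
Compound 2 `N/C(=N\NC(=S)N1CCCCCC1)c1ccccn1`: 72.3%
Compound 3 `Cc1ccnc(/C(N)=N/NC(=S)N2CCCCCC2)c1`: 63.4%

In a functional assay on A-431 cells (Homo sapiens) for cytotoxicity, read by MTT assay, with a stated time of 72 h, tested at 30 uM (on this read-out lower numbers stand for less inhibition of growth and higher numbers for more inhibition of growth at the one concentration tested), compound 2 gives the highest of the three numbers; compound 3 sits within the scatter of it, while compound 1 sits beyond it. Compound 4 `Cc1cccc(/C(N)=N/NC(=S)N2CCCCCC2)n1` has not yet been measured. It differs from compound 2 by methyl in place of hydrogen on an aromatic carbon. One measured step is of the same kind, methyl in place of hydrogen on an aromatic carbon, and it gave a number 8.9 percentage points lower from compound 2 to compound 3 (within the scatter), a change within the scatter. Compound 1 carries the same methyl as compound 4 but a different amine part, so it offers no clean comparison. The step of a number 6.3 percentage points lower from compound 2 to compound 4 (within the scatter) is therefore expected to stay within the scatter. The estimate for compound 4 is 66%, ranging from 52% to 78%.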

Compound 4, percent growth inhibition at one concentration: 63.5%
Compound 4: the middle estimate sits 2.5 percentage points above what was measured; the measured number falls inside the stated range.
By their numbers in this assay, from the lowest: compounds 1, 3, 4 and 2 (each within the scatter of the next, the first and the last beyond it).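

In this assay, placing methyl in place of hydrogen next to the ring nitrogen gives a number 8.8 percentage points lower from compound 2 to compound 4 (within the scatter). This is a second ring carbon where the same swap stays within the scatter: compound 3, with its methyl on a different ring carbon, gives 63.4% and compound 4 gives 63.5%, so these two placements cannot be told apart here. No supporting measurement explains this outcome.

Going by these compounds, whether an ethyl group or an amine on this same carbon would also stay within the scatter remains open.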